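The source may hold more compounds than are shown below. What is called first, only, known or untested is meant among the compounds shown, and "the series" means these compounds.

Two compounds sharing a chlorinated, tetrazole-bearing benzyl amide have been measured in an ADME assay on Caco-2 cells (Homo sapiens) for permeability, read by LC-MS, in the apical to basolateral direction, with a stated time of 60 min, at pH 6.5 (on this read-out lower numbers stand for lower permeability and higher numbers for higher permeability), so far. Compound 1 (`Cc1cccc([C@@H](O)C(=O)N2N=CC[C@H]2C(=O)NCc2cc(Cl)ccc2-n2cnnn2)c1`) gives 9.7 10^-6 cm/s in this assay and compound 2 (`O=C(NCc1cc(Cl)ccc1-n1cnnn1)[C@@H]1CCNN1C(=O)[C@H](O)c1ccccc1`) gives 5.3 10^-6 cm/s there. Going by the values given here, compound 2 thus stands within the usual scatter of compound 1, the only other compound with a number, and the two values cannot be told apart.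

Compound 3 (`CC(C)(C)[C@@H](O)C(=O)N1NCC[C@H]1C(=O)NCc1cc(Cl)ccc1-n1cnnn1`) has not yet been measured. Compared with compound 2 it carries tert-butyl in place of phenyl on a saturated chain carbon bound to a carbonyl carbon and an oxygen on a saturated carbon with the rest of the structure unchanged. Among the compounds with values here, no measured pair differs in only one place, so the data give no direct size for such a change. The expectation therefore rests on compound 2 at 5.3 10^-6 cm/s as its starting point, with no direction favoured and no shift beyond the scatter foreseen. The expected change is a 1.1-fold lower number from compound 2 to compound 3 (0.03 log units; within the scatter) and so remains small. For compound 3 the estimated value is 5 10^-6 cm/s with an expected range from 2.2 10^-6 cm/s to 11 10^-6 cm/s in this assay when the measurement is made.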

Compound 3, apparent permeability: 7.2 10^-6 cm/s
Compound 3: middle estimate off by 1.4-fold (0.16 log units), on the low side, within the range that was stated.
By their numbers in this assay, from the lowest: compounds 2, 3 and 1 (each within the scatter of the next).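

Read in this assay, tert-butyl in place of phenyl on a saturated chain carbon bound to a carbonyl carbon and an oxygen on a saturated carbon gives a 1.4-fold higher number from compound 2 to compound 3 (0.13 log units; within the scatter) and provides the first pair in this set that differs in one place. At this position, therefore, a six-membered aromatic ring of carbon only and a group with no ring, neither carrying hydrogen-bond donors or acceptors nor a net charge, give numbers that cannot be told apart, though this rests on a single pair and claims nothing about other groups. No supporting measurement bears on this step, so the data offer no explanation for the reading.

The compounds shown leave open whether an amine or a carboxylic acid at this position, each a group that brings heteroatoms where phenyl and tert-butyl have only carbon, would also stay within the scatter of compound 2. They also leave open whether a longer chain or a cyclohexyl ring would do so, and compound 1 differs from compound 2 and compound 3 in more than one place, so it cannot settle either question.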